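From a 5-cyanopentyl chain to cyclobutyl

The compounds below may be only part of what the source reports. "The series", "measured", "known", "first", "only" and "open" are said of these compounds alone.

Three compounds so far have numbers in a functional assay on HT-29 cells (Homo sapiens) for inhibition, read by luminescence and CellTiter-Glo, with a stated time of 24 h (on this read-out higher numbers stand for an effect only at larger amounts of compound and lower numbers for an effect already at smaller amounts), and they share one core

Compound 1 (`CC(C)n1nc(C(=O)N[C@H]2COc3ccccc3N(C)C2=S)nc1Cc1ccccc1`) gives 360 nM
Compound 2 (`CC(C)Cn1nc(C(=O)N[C@H]2COc3ccccc3N(C)C2=S)nc1Cc1ccccc1`) gives 1230 nM
Compound 3 (`CN1C(=S)[C@@H](NC(=O)c2nc(Cc3ccccc3)n(CCCCCC#N)n2)COc2ccccc21`) gives 3830 nM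

Compound 3 has the highest of the three numbers, with compound 2 the nearest to it and compound 1 the furthest. Compound 4 (`CN1C(=S)[C@@H](NC(=O)c2nc(Cc3ccccc3)n(C3CCC3)n2)COc2ccccc21`) carries cyclobutyl in place of 5-cyanopentyl on an aromatic nitrogen and is otherwise the same. Neither compound 1 nor compound 2 has the nitrile chain, and both stand lower than compound 3. Among the measured compounds shown here, the steps that bear on the change are an 11-fold higher number from compound 1 to compound 3 (1.03 log units; beyond the scatter) which is large, and a 3.1-fold higher number from compound 2 to compound 3 (0.49 log units; beyond the scatter) which is modest. Between the two groups without a nitrile, a 3.4-fold higher number from compound 1 to compound 2 (0.53 log units; beyond the scatter) is also modest. Leaving the chain is therefore expected to lower the number, by a modest to large step. For compound 4 the expected step is a 7.0-fold lower number from compound 3 to compound 4 (0.84 log units; beyond the scatter) in this assay as an estimate only. The estimate for compound 4 is 550 nM with an expected range from 170 nM to 1700 nM for now.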

Compound 4, half-maximal effective concentration: 181 nM
Beside the measured number, compound 4's estimate is 3.0-fold (0.48 log units) above it; measured number inside the range.
By their numbers in this assay, from the lowest: compounds 4 and 1 (each within the scatter of the next); then compound 2; then compound 3.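

In this assay compound 4 is the only one of the four with a ring on the aromatic nitrogen, and cyclobutyl there gives a 21-fold lower number from compound 3 to compound 4 (1.33 log units; beyond the scatter) when it replaces 5-cyanopentyl and a 6.8-fold lower number from compound 2 to compound 4 (0.83 log units; beyond the scatter) when it replaces isobutyl. When it replaces isopropyl, the result is a 2.0-fold lower number from compound 1 to compound 4 (0.30 log units; within the scatter), so these two groups cannot be told apart at this position and compound 1 and compound 4 share the low end of the series. No measurement at hand gives a reason for these steps.

From the compounds shown here alone, whether cyclopropyl or cyclohexyl would stand level with cyclobutyl remains open. So does whether the high number of compound 3 goes with the nitrile or with the chain, which a plain hexyl chain could help to separate.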